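Exchanging a difluorophenyl for a pyrimidinyl on the cyclopropane

The compounds below may be only part of what the source reports. "The series", "measured", "known", "first", "only" and "open" are said of these compounds alone.

Going by the values given here, compound 2 `CC[C@H](C)[C@H](N)CN(C(=O)[C@@H]1C[C@H]1c1cc(F)ccc1F)c1ccc(-c2ccccc2)cc1` is one of two compounds measured in a functional assay for agonist activity at G protein-coupled receptor 88 (Homo sapiens), read by HTRF and cAMP accumulation; a higher number here means that more compound is needed for the effect, a lower number that less compound is needed; there compound 2 gives 770 nM, the higher of the two numbers. Its nearest neighbour is compound 1 `CC[C@H](C)[C@H](N)CN(C(=O)[C@@H]1C[C@H]1c1ccccc1F)c1ccc(-c2ccccc2)cc1`, which in this assay gives 650 nM; the step of a 1.2-fold higher number from compound 1 to compound 2 (0.07 log units; within the scatter). Compound 3 `CC[C@H](C)[C@H](N)CN(C(=O)[C@@H]1C[C@H]1c1cncnc1)c1ccc(-c2ccccc2)cc1` is not yet measured. It differs from compound 2 in one place: pyrimidin-5-yl in place of 2,5-difluorophenyl on a saturated ring carbon. Among the compounds with values here, the single measured step concerns only a fluoro in place of hydrogen on an aromatic carbon and lies within the scatter, so it says little about replacing the whole ring. Within the data shown here, no measured pair bears directly on this change, and the expectation rests on weak ground. Compound 3 is therefore expected to give 1500 nM in this assay, within 400 nM to 6000 nM. That estimate means a step of a 1.9-fold higher number from compound 2 to compound 3 (0.29 log units; within the scatter), expected with low confidence.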

Compound 3, half-maximal effective concentration: 19000 nM
Beside the measured number, compound 3's estimate is 13-fold (1.10 log units) below it; the measured number lies above the stated range.
By their numbers in this assay, from the lowest: compounds 1 and 2 (each within the scatter of the next); then compound 3.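

In this assay, the ring on this saturated ring carbon proves far from indifferent: pyrimidin-5-yl in place of 2,5-difluorophenyl gives a 25-fold higher number from compound 2 to compound 3 (1.39 log units; beyond the scatter), and pyrimidin-5-yl in place of 2-fluorophenyl gives a 29-fold higher number from compound 1 to compound 3 (1.47 log units; beyond the scatter). Adding a fluoro to the aromatic ring had shown only a step within the scatter, whereas exchanging a six-membered aromatic ring of carbon only for one with 2 hetero atoms gives a large step, whichever fluorophenyl is the starting point. Nothing at hand bears on what lies behind this step.

The compounds shown leave open whether the step follows from the ring nitrogens or from the absence of fluorine; a plain phenyl or a pyridin-3-yl on the same carbon would separate the two. Also open, as far as these compounds go, is how a saturated ring such as cyclohexyl would fare at this position.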